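Azido Gives Way to Amino in Compound 2

The compounds below may be only part of what the source reports. "The series", "measured", "known", "first", "only" and "open" are said of these compounds alone.

Within the data shown here, in a functional assay on OCI-AML2 cells (Homo sapiens) for antiproliferative activity, read by WST assay, with a stated time of 3 days (a higher number here means a weaker inhibitor, a lower number a stronger inhibitor), compound 2 (`[N-]=[N+]=Nc1c(F)c(=O)[nH]c(=O)n1[C@@H]1O[C@H](CO)[C@@H](O)[C@H]1O`) gives 700 nM, the only true number so far. Compound 1 (`Nc1cc(=O)[nH]c(=O)n1[C@@H]1O[C@H](CO)[C@@H](O)[C@H]1O`), which also bears amino but has no fluoro group, reads > 50000 nM, and this is a limit of the assay. Compound 3 (`Nc1c(F)c(=O)[nH]c(=O)n1[C@@H]1O[C@H](CO)[C@@H](O)[C@H]1O`) has amino in place of azido on an aromatic carbon, ortho to a fluoro group: amino in place of azido on an aromatic carbon. The limit of compound 1 at > 50000 nM suggests caution, so a weakening in this assay is expected, of a size beyond the scatter. The expected step is a 3.6-fold higher number from compound 2 to compound 3 (0.55 log units; beyond the scatter). For compound 3 the estimate is 2500 nM, with an expected range of 300 nM to 30000 nM.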

Compound 3, half-maximal inhibitory concentration: 900 nM
Estimate against measurement, compound 3: 2.8-fold (0.44 log units) above; the range from low to high includes it.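

Replacing azido with amino at this position changes little in this assay, with a 1.3-fold higher number from compound 2 to compound 3 (0.11 log units; within the scatter), so azido is not required for the activity of compound 2. With amino held in place, fluoro in place of hydrogen gives an at least 55-fold lower number from compound 1 to compound 3 (1.74 log units; beyond the scatter), so the fluoro group matters far more here than the choice between azido and amino. The size of this step is uncertain, as compound 1 gives only a limit, not a true number: the limit of > 50000 nM in this assay, at which 1 of the 3 values shown sits.

On these data alone, whether chlorine or a methyl group could stand in for the fluoro group remains open. So does whether a methylamino group would keep the activity of compound 3.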